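A methoxyphenyl in place of a methylsulfanylphenyl

The source may hold more compounds than are shown below. What is called first, only, known or untested is meant among the compounds shown, and "the series" means these compounds.

Compound 3 `CSc1ccccc1NC(=S)N1CCc2c(sc(NC(=O)c3ccccc3Cl)c2C(N)=O)C1` sits second highest of the three numbers in a functional assay on HL-60 cells (Homo sapiens) for antiproliferative activity, with a stated time of 24 h; on this read-out lower numbers stand for stronger inhibition and higher numbers for weaker inhibition: compound 2 `Cc1ccccc1NC(=S)N1CCc2c(sc(NC(=O)c3ccccc3Cl)c2C(N)=O)C1` gives 22600 nM, compound 3 gives 14600 nM, and compound 1 `NC(=O)c1c(NC(=O)c2ccccc2Cl)sc2c1CCN(Cc1c(Cl)cccc1Cl)C2` gives 4850 nM. The step of a 1.5-fold lower number from compound 2 to compound 3 (0.19 log units; within the scatter) falls within the scatter, while a 3.0-fold higher number from compound 1 to compound 3 (0.48 log units; beyond the scatter) and a 4.7-fold higher number from compound 1 to compound 2 (0.67 log units; beyond the scatter) lie beyond it. Compound 4 `COc1ccc(NC(=S)N2CCc3c(sc(NC(=O)c4ccccc4Cl)c3C(N)=O)C2)cc1` differs from compound 3 by 4-methoxyphenyl in place of 2-(methylsulfanyl)phenyl on an amide-type nitrogen. Within the data shown here, only the step of a 1.5-fold lower number from compound 2 to compound 3 (0.19 log units; within the scatter) alters the same ring, and it stayed within the scatter; no measured compound carries a methoxy group, so nothing points to a larger move. The expected step is therefore a 1.0-fold higher number from compound 3 to compound 4 (0.01 log units; within the scatter), none beyond the scatter. Compound 4 is estimated at 15000 nM, with a range from 5000 nM to 45000 nM.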

Compound 4, half-maximal inhibitory concentration: 15700 nM
For compound 4 the middle estimate is 1.0-fold (0.02 log units) below the measured one, and the stated range covers the measured number.
By their numbers in this assay, from the lowest: compound 1; then compounds 3, 4 and 2 (each within the scatter of the next).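

In this assay, moving from 2-(methylsulfanyl)phenyl to 4-methoxyphenyl on the amide-type nitrogen leaves the numbers within the scatter (a 1.1-fold higher number from compound 3 to compound 4 (0.03 log units; within the scatter)), as does moving from 2-methylphenyl (a 1.4-fold lower number from compound 2 to compound 4 (0.16 log units; within the scatter)). This nitrogen has now carried an oxygen-bearing group, with the substituent named at a different ring position, and compounds 2, 3 and 4 still cannot be told apart, while compound 1 keeps its gap (a 3.2-fold higher number from compound 1 to compound 4 (0.51 log units; beyond the scatter)). Nothing available explains this result.

From the compounds shown here alone, whether 2-methoxyphenyl would match 4-methoxyphenyl remains open. So does whether a phenyl ring carrying an amine or a carboxylic acid, or a cyclohexyl group, would stay within this narrow band.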